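Replacing the Ester Oxygen with an Amide Nitrogen

This account rests on a few compounds, and the source may have more. Where it says the series, first, only, none or still open, it means among the compounds named here.

Compound 1, `COc1ccc(OC)c(C(=O)/C=C/c2ccc(C(=O)O)cc2)c1`, gives 7240 nM in a functional assay on PC-3 cells (Homo sapiens) for cytotoxicity, read by MTT assay, with a stated time of 72 h; a lower number here means a stronger inhibitor, a higher number a weaker inhibitor.
Compound 2, `COc1ccc(OC)c(C(=O)/C=C/c2ccc(C(=O)OC(C)C)cc2)c1`, gives 6740 nM.
Compound 3, `COc1ccc(OC)c(C(=O)/C=C/c2ccc(C(=O)OCc3ccccc3)cc2)c1`, gives 18000 nM.

Compound 2 has the lowest of the three numbers in this assay, but its gap to compound 1, a 1.1-fold lower number from compound 1 to compound 2 (0.03 log units; within the scatter), is within the scatter, so the two cannot be told apart. Only compound 3 stands clearly apart: a 2.7-fold higher number from compound 2 to compound 3 (0.43 log units; beyond the scatter) and a 2.5-fold higher number from compound 1 to compound 3 (0.40 log units; beyond the scatter).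

The next compound, compound 4, `COc1ccc(OC)c(C(=O)/C=C/c2ccc(C(=O)NC(C)C)cc2)c1`, differs from compound 2 in one place: isopropylamino in place of isopropoxy on a carbonyl carbon. The three measured steps all exchange the group on the oxygen of the ester and leave the oxygen itself in place, so none of them tests the change from isopropoxy to isopropylamino. The measured steps do show that the group beyond the carbonyl matters only modestly at most.

For the measured compounds named here, with no direct precedent, a step of no more than the scatter is expected, in either direction, so compound 4 is estimated at 6500 nM, with a range from 2500 nM to 17000 nM, meaning an expected step of a 1.0-fold lower number from compound 2 to compound 4 (0.02 log units; within the scatter).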

Compound 4, half-maximal inhibitory concentration: 1580 nM
For compound 4 the middle estimate is 4.1-fold (0.61 log units) above the measured one, and the stated range ends above it.
By their numbers in this assay, from the lowest: compound 4; then compounds 2 and 1 (each within the scatter of the next); then compound 3.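

For the compounds shown here, this is the first step to change the atom joining the side group to the carbonyl carbon: with the isopropyl group kept, isopropylamino in place of isopropoxy gives a clear gain in this assay (a 4.3-fold lower number from compound 2 to compound 4 (0.63 log units; beyond the scatter)). That gain sets the amide apart from the acid (a 4.6-fold lower number from compound 1 to compound 4 (0.66 log units; beyond the scatter)) and even further from the benzyl ester (an 11-fold lower number from compound 3 to compound 4 (1.06 log units; beyond the scatter)), so compound 4 has the lowest number of the four, and this position responds to the joining atom as well as to the group beyond it. Nothing available explains why the amide gives the lower number.

As far as these compounds go, whether benzylamino would improve on benzyloxy in the same way remains open. So does whether the gain survives in a simple unsubstituted amide or in a dimethylamino amide, which lacks the amide hydrogen.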